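Swapping Oxetanyl for Cyclohexyl on the Amide Nitrogen

The source may report more compounds than this note shows. Statements on the series, on what has been measured and on what is new or still open speak of the compounds shown alone.

Compound 1 `Cc1ccc(OCC(=O)N(Cc2cccs2)C2COC2)cc1` gives 23000 nM in an assay on HEK293 cells for agonist activity at transient receptor potential cation channel subfamily M member 8 (Homo sapiens), read by fluorescence and calcium flux, with a stated time of 15 min; a higher number here means that more compound is needed for the effect, a lower number that less compound is needed.
Compound 2 `CCN(Cc1cccs1)C(=O)/C=C/c1ccc(C)cc1` gives 2 nM.
Compound 3 `O=C(COc1ccc2c(c1)CCC2)N(Cc1cccs1)c1ccn[nH]1` gives 0.001 nM.

Compound 1 stands at the highest number of the three; compound 2 lies far lower, and compound 3 lower still, both gaps well beyond the scatter. Compound 4 `Cc1ccc(OCC(=O)N(Cc2cccs2)C2CCCCC2)cc1` differs from compound 1 in one place: cyclohexyl in place of oxetan-3-yl on an amide-type nitrogen. Among the measured compounds shown here, no measured pair shows this exact change, so the size of the step is uncertain. Still, compound 2 at 2 nM and compound 3 at 0.001 nM carry different groups on the same nitrogen and reach much lower numbers, so a drop beyond the scatter is expected for compound 4, giving a 12-fold lower number from compound 1 to compound 4 (1.06 log units; beyond the scatter). Compound 4 is therefore estimated at 2000 nM, within a range from 200 nM to 20000 nM.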

Compound 4, half-maximal effective concentration: 40000 nM
Beside the measured number, compound 4's estimate is 20-fold (1.30 log units) below it, and the stated range ends below it.
By their numbers in this assay, from the lowest: compound 3; then compound 2; then compounds 1 and 4 (each within the scatter of the next).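

On the amide-type nitrogen, cyclohexyl in place of oxetan-3-yl gives a 1.7-fold higher number from compound 1 to compound 4 (0.24 log units; within the scatter) in this assay and so does not separate the two compounds. With this core, a four-membered ring holding one oxygen and a six-membered ring of carbon only therefore read alike, even though ring size and the oxygen change together. Nothing available gives a reason for this result.

Going by these compounds, whether ring size and the oxygen each matter alone, perhaps cancelling out, stays open. So does how a tetrahydropyran-4-yl group or an azetidin-3-yl group would read at this nitrogen.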